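Inverting four stereocentres of the most potent urea

The source may report more compounds than this note shows. Statements on the series, on what has been measured and on what is new or still open speak of the compounds shown alone.

Measured compounds:
compound 1 `C[C@@H]1CN(CCCN(C(=O)Nc2cc(Cl)nc(Cl)c2)[C@@H]2CC[C@]3(c4cnc(CN)s4)CC23)[C@@H](C)CN1`, 13.1 nM
compound 2 `C[C@@H]1CN(CCCN(C(=O)Nc2cc(Cl)nc(Cl)c2)[C@H]2CC[C@@]3(c4cnc(CN)s4)C[C@@H]23)[C@@H](C)CN1`, 117 nM
compound 3 `C[C@@H]1CN(CCCN(C(=O)Nc2cc(Cl)nc(Cl)c2)[C@H]2CC[C@]3(c4cnc(CN)s4)C[C@H]23)[C@@H](C)CN1`, 6.1 nM

In a functional assay for antagonist activity at melanin-concentrating hormone receptor 1 (Homo sapiens) (a higher number here means a weaker inhibitor, a lower number a stronger inhibitor), compound 3 gives the lowest number of the three. Its nearest neighbour is compound 1, with a 2.1-fold lower number from compound 1 to compound 3 (0.33 log units; beyond the scatter), and its furthest is compound 2, with a 19-fold lower number from compound 2 to compound 3 (1.28 log units; beyond the scatter). The step from compound 1 to compound 2 gave an 8.9-fold higher number from compound 1 to compound 2 (0.95 log units; beyond the scatter).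

Compound 4 `C[C@@H]1CN[C@@H](C)CN1CCCN(C(=O)Nc1cc(Cl)nc(Cl)c1)[C@H]1CC[C@@]2(c3cnc(CN)s3)C[C@@H]12` keeps every atom and bond of compound 3; the difference is the two compounds have the same atoms and bonds and differ only in configuration as drawn: 4 of 5 stereo elements differ; a stereocentre at a saturated ring carbon is drawn S in compound 3 and R in compound 4; a stereocentre at a saturated ring carbon is drawn R in compound 3 and S in compound 4; a stereocentre at a saturated ring carbon is drawn S in compound 3 and R in compound 4; a stereocentre at a saturated ring carbon is drawn S in compound 3 and R in compound 4. The two measured steps that rest purely or mainly on configuration, a 19-fold lower number from compound 2 to compound 3 (1.28 log units; beyond the scatter) and an 8.9-fold higher number from compound 1 to compound 2 (0.95 log units; beyond the scatter), both show that swapping the ring configurations moves this assay by a modest to large amount, and compound 3 sits at the favourable end of that series. Reversing most of its stereocentres is therefore expected to raise the number, and the step from compound 3 to compound 4 is estimated as a 13-fold higher number from compound 3 to compound 4 (1.12 log units; beyond the scatter). Compound 4 is expected to give 80 nM in this assay, with a range from 20 nM to 320 nM.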

Compound 4, inhibition constant: 171 nM
Compound 4: middle estimate off by 2.1-fold (0.33 log units), on the low side; low and high end bracket the measured number.
By their numbers in this assay, from the lowest: compound 3; then compound 1; then compounds 2 and 4 (each within the scatter of the next).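

In this assay, reversing four stereocentres at once gives a 28-fold higher number from compound 3 to compound 4 (1.45 log units; beyond the scatter), and compound 4 falls in with compound 2 rather than with the better compounds. With a 1.5-fold higher number from compound 2 to compound 4 (0.16 log units; within the scatter), the two centres that separate this pair produce no readable change, so compound 4 adds a second configuration that sits at the unfavourable end of the series, and the difference here rests on configuration alone: the fact that compounds 2 and 4 differ only in the configuration as drawn. Against compound 1 the result is a 13-fold higher number from compound 1 to compound 4 (1.12 log units; beyond the scatter), but that comparison is less clean, as one centre in compound 1 has no drawn configuration: the fact that one of compounds 1 and 4 is drawn with a defined configuration and the other without, at the place where they differ.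

How each centre acts alone stays open, as every pair shown differs at two or more of them. From the compounds shown here alone, it is also open whether the preference for the configuration of compound 3 would hold with a carboxylic acid or a longer chain in place of the aminomethyl group.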